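This account rests on a few compounds, and the source may have more. Where it says the series, first, only, none or still open, it means among the compounds named here.

Compound 1, `CN1CCC[C@H]1[C@@H]1COc2ccc(N)cc2O1`, gives 22 nM in an assay on membranes from Cerebral cortex for displacement of a labelled ligand from Neuronal acetylcholine receptor; alpha4/beta2 (Rattus norvegicus), with a stated time of 5 min (a higher number here means a weaker inhibitor, a lower number a stronger inhibitor), the lowest of the three numbers recorded. Compound 2, `CN1CCC[C@H]1[C@H]1COc2ccc(N)cc2O1`, differs from it only in configuration as drawn and gives 140 nM in this assay, a step of a 6.4-fold higher number from compound 1 to compound 2 (0.80 log units; beyond the scatter); this rests on (the fact that compounds 1 and 2 differ only in the configuration as drawn). Compound 3, `CN1CCC[C@H]1[C@@H]1COc2cc(N)ccc2O1`, which carries the amino group on a different aromatic carbon of the shared core, gives 86000 nM in this assay, far above compound 1.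

Compound 4, `CN1CCC[C@H]1[C@@H]1COc2ccc([N+](=O)[O-])cc2O1`, is reached from compound 1 by a different kind of change: nitro in place of amino on an aromatic carbon. Neither measured step bears directly on this exchange. The step from compound 1 to compound 2 concerns configuration alone, and the gap between compound 1 and compound 3 concerns the position of the amino group, not its identity. Among the compounds with values here, with no measured precedent for nitro in place of amino, compound 4 is expected to lie somewhat above compound 1, a step of a 3.6-fold higher number from compound 1 to compound 4 (0.56 log units; beyond the scatter). In this assay compound 4 is therefore estimated at 80 nM, with a range from 15 nM to 400 nM.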

Compound 4, inhibition constant: 14000 nM
The estimate for compound 4 lay 180-fold (2.24 log units) below the measured number; measured number outside the range, above it.
By their numbers in this assay, from the lowest: compound 1; then compound 2; then compound 4; then compound 3.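

In this assay, exchanging amino for nitro on this aromatic carbon brings a step of a 640-fold higher number from compound 1 to compound 4 (2.80 log units; beyond the scatter). The earlier compounds shown here showed that configuration and the place of the amino group count, whereas this pair shows that, with place and configuration held fixed, the identity of the group also counts, and the step is larger than that of a 6.4-fold higher number from compound 1 to compound 2 (0.80 log units; beyond the scatter). Nothing known about these compounds accounts for the exchange, as the only available fact concerns configuration.

The compounds shown do not separate the loss of amino from the entry of nitro as the source of this step. From the compounds shown here alone, how a hydroxyl, a methoxy or an acetamide on this carbon would read in this assay remains open, as does whether nitro would give a similar step in the configuration of compound 2.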